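Series notes: from compound 2 to compound 3

The compounds below may be only part of what the source reports. "The series", "measured", "known", "first", "only" and "open" are said of these compounds alone.

Measured compounds:
compound 1 `COc1ccc(-c2nc(C)oc2C(=O)N2CCN(c3cccc(Cl)c3)CC2)cc1O` — "not active" (no number reported) in a functional assay on HL-60 cells (Homo sapiens) for inhibition, read by MTT assay, with a stated time of 72 h; on this read-out higher numbers stand for weaker inhibition and lower numbers for stronger inhibition
compound 2 `Cc1nc(-c2ccccc2)c(C(=O)N2CCN(c3cccc(C(F)(F)F)c3)CC2)o1` — 153 nM in this assay

Within the data shown here, compound 2 stands as the only entry with a number in this assay; compound 1 is reported without one, so nothing can be said about how the two compare. Compound 3 `Cc1nc(-c2ccccc2)c(C(=O)N2CCN(c3cccc(F)c3)CC2)o1` is not yet measured. It differs from compound 2 in one place: fluoro in place of trifluoromethyl on an aromatic carbon. Among the measured compounds shown here, no pair of measured compounds differs in a single place, so no measured step is available to set the size of such a change. From the two structures alone, a modest loss of potency is expected, with the step from compound 2 to compound 3 estimated at a 2.3-fold higher number from compound 2 to compound 3 (0.36 log units; beyond the scatter), a step that could still fall within the scatter. For compound 3 the expected value in this assay is 350 nM, with a range from 120 nM to 1200 nM.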

Compound 3, half-maximal inhibitory concentration: 45 nM
For compound 3 the middle estimate is 7.8-fold (0.89 log units) above the measured one, outside the stated range (below it).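

In this assay, among these compounds, replacing 3-(trifluoromethyl)phenyl with 3-fluorophenyl gives a 3.4-fold lower number from compound 2 to compound 3 (0.53 log units; beyond the scatter), the only measured step that changes a single place. At this aromatic carbon, then, trifluoromethyl is not required for activity in this assay, and fluoro gives the stronger inhibition of the two groups. Nothing in the available data accounts for this step.

As far as these compounds go, only these two groups can be compared at this carbon, so it remains open whether an unsubstituted phenyl, or a methoxy or nitrile at the same carbon, would continue or break the direction of this step on the shared core. Compound 1 differs from compound 2 and compound 3 in more than one place, so its result cannot show what any single change does.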